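The source may report more compounds than this note shows. Statements on the series, on what has been measured and on what is new or still open speak of the compounds shown alone.

Of the compounds shown here, three sharing one core have been measured for cytotoxicity. In an ADME assay on SK-OV-3 cells (Homo sapiens) for cytotoxicity, read by sulforhodamine B assay, with a stated time of 48 h, tested at 10 uM (on this read-out higher numbers stand for more inhibition at the one concentration tested (going by the name of the read-out) and lower numbers for less inhibition), compound 1 `COc1nc2ccc(Br)cc2cc1C(c1ccccc1)n1cc(-c2ccccc2)nn1` gives 13.7%, compound 2 `CCCc1cn(C(c2ccccc2)c2cc3cc(Br)ccc3nc2OC)nn1` gives 11.2%, and compound 3 `COc1nc2ccc(Br)cc2cc1C(c1ccccc1)n1cc(CCO)nn1` gives 8.46%. On these numbers compound 3 stands lowest of the three, but every gap between them lies within the scatter of repeated measurements: a number 2.5 percentage points lower from compound 1 to compound 2 (within the scatter), a number 5.2 percentage points lower from compound 1 to compound 3 (within the scatter) and a number 2.7 percentage points lower from compound 2 to compound 3 (within the scatter). In other words, swapping the group on the triazole between phenyl, propyl and 2-hydroxyethyl has so far produced nothing that can be told apart from noise.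

Compound 4 `COc1nc2ccc(Br)cc2cc1C(c1ccccc1)n1cc(C2CC2)nn1` continues this series with a new group in the same place: cyclopropyl in place of 2-hydroxyethyl on an aromatic carbon. The 2-hydroxyethyl chain, which carries one hydrogen-bond donor and one hydrogen-bond acceptor, gives way to a small three-membered ring of carbon only, with no donor or acceptor. Among the measured compounds shown here, the steps that bear on this are the three above, each within the scatter; none of them points to a group at this position moving the read-out in a clear direction, and there is no measured step for a cyclopropyl group here.

Accordingly no step beyond the scatter is expected: the estimated step of a number 2.5 percentage points higher from compound 3 to compound 4 (within the scatter) stays within the usual spread. Compound 4 is expected to give about 11%, in a range from 3% to 21%.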

Compound 4, a percentage reported as inhibition, at one concentration (the size of the read-out at that concentration, not a potency): 3.52%
Beside the measured number, compound 4's estimate is 7.5 percentage points above it; the range from low to high includes it.
By their numbers in this assay, from the lowest: compounds 4, 3, 2 and 1 (each within the scatter of the next, the first and the last beyond it).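

Cyclopropyl gives the first pair at this position that can be told apart in this assay: with cyclopropyl in place of phenyl, the result is a modest step (a number 10.2 percentage points lower from compound 1 to compound 4 (beyond the scatter)). The other two steps stay within the scatter (a number 4.9 percentage points lower from compound 3 to compound 4 (within the scatter)) and (a number 7.7 percentage points lower from compound 2 to compound 4 (within the scatter)), so cyclopropyl cannot be separated from 2-hydroxyethyl or propyl, even though 2-hydroxyethyl carries a hydrogen-bond donor and a hydrogen-bond acceptor and cyclopropyl carries neither; only the phenyl and cyclopropyl compounds stand apart, while compound 2 and compound 3 lie within the scatter of both. Nothing available explains the gap between compound 1 and compound 4.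

From the compounds shown here alone, it remains open whether a larger aromatic ring, such as naphthyl, would widen that gap, or whether an amine, a carboxylic acid or a longer carbon chain at this position would shift the read-out clearly away from all four compounds. Since each number comes from a single concentration, the four compounds also leave open how their potencies compare.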